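A few compounds are considered here, and "the series" means these few. Any claim that something is new, unique, unknown or untested is made for them only; others in the source may bear on it.

Measured in a functional assay on RAW264.7 cells (Mus musculus) for inhibition, with a stated time of 30 min; a higher number here means a weaker inhibitor, a lower number a stronger inhibitor:

Compound 1 `C=C1C(=O)OC[C@H]1CCOC(=O)Nc1ccc(I)cc1`: 490 nM
Compound 2 `C=C1C(=O)OC[C@@H]1CCOC(=O)Nc1ccc(I)cc1`: 790 nM
Compound 3 `C=C1C(=O)OC[C@@H]1CCOC(=O)Nc1ccc(CCCC)cc1`: 1230 nM

Compound 1 gives the lowest of the three numbers. Compound 2 sits nearest, a 1.6-fold higher number from compound 1 to compound 2 (0.21 log units; within the scatter); (the fact that compounds 1 and 2 differ only in the configuration as drawn). Compound 3 stands furthest from compound 1, a gap beyond the scatter.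

Compound 4 `C=C1C(=O)OC[C@H]1CCOC(=O)Nc1ccc(C(C)C)cc1` is not yet measured. Against compound 1 the change is isopropyl in place of iodo on an aromatic carbon. The measured step that bears on it is the exchange of iodo for an alkyl group at an aromatic carbon, a 1.6-fold higher number from compound 2 to compound 3 (0.19 log units; within the scatter), which stayed within the scatter. A step of similar size, toward a higher number, is expected in this assay, so a 1.5-fold higher number from compound 1 to compound 4 (0.18 log units; within the scatter) is the expectation. Compound 4 is therefore estimated at 750 nM, with a range of 350 nM to 1600 nM.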

Compound 4, half-maximal inhibitory concentration: 340 nM
Estimate against measurement, compound 4: 2.2-fold (0.34 log units) above, and the stated range ends above it.
By their numbers in this assay, from the lowest: compounds 4, 1, 2 and 3 (each within the scatter of the next, the first and the last beyond it).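

Isopropyl in place of iodo on the aromatic carbon gives a 1.4-fold lower number from compound 1 to compound 4 (0.16 log units; within the scatter) in this assay, so at this position 3 carbon atoms stand in for 1 iodine atom with no step beyond the scatter. With a 1.6-fold higher number from compound 2 to compound 3 (0.19 log units; within the scatter) as the earlier case, the exchange of iodo for an alkyl group now stays within the scatter in both drawn configurations. No measurement at hand bears on what lies behind this step.

Still open, from the compounds shown here alone, is how an amine or a carboxylic acid at this position would read in this assay. Going by these compounds, a chain longer than butyl is equally open.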